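A few compounds are considered here, and "the series" means these few. Any claim that something is new, unique, unknown or untested is made for them only; others in the source may bear on it.

The account follows one step in an assay on HEK293 cells for inhibition of transient receptor potential cation channel subfamily M member 8 (Homo sapiens), read by FLIPR, with stated times of 5 min and 3 min (a higher number here means a weaker inhibitor, a lower number a stronger inhibitor), from compound 1 to compound 4. Compound 1 `CON(C)C(=O)c1sc(-c2ccccc2O)nc1O` stands lowest of the three numbers measured: in this assay compound 1 gives 66 nM. Compound 2 `CCN(C)C(=O)c1sc(-c2ccccc2)nc1O` gives 6400 nM in this assay, and compound 3 `O=C(c1sc(-c2cccc(F)c2)nc1O)N1CCOCC1` gives 12200 nM; both lie far beyond the scatter from compound 1, yet each differs from compound 1 in more than one place, so no single change can be read from them. Compound 4 `O=C(c1sc(-c2ccccc2O)nc1O)N1CCCCO1` has not been measured. It differs from compound 1 in one place only: a group of 6 heavy atoms (4 carbon, 1 nitrogen, 1 oxygen; one six-membered non-aromatic ring with 2 hetero atoms) in place of a group of 4 heavy atoms (2 carbon, 1 nitrogen, 1 oxygen; no ring), on a carbonyl carbon. The methoxy(methyl)amino group is thus exchanged for a ring closed through the same nitrogen and oxygen, on the carbonyl carbon that sits on an aromatic carbon, while the remainder of compound 1 is kept. For the measured compounds named here, no pair of measured compounds differing in a single place is available, so the size of such a step cannot be taken from a comparable case. Since the only changed part is the group on the carbonyl carbon, the step is estimated as a 2.3-fold higher number from compound 1 to compound 4 (0.36 log units; beyond the scatter), a small move toward weaker inhibition that may not exceed the scatter. Compound 4 is therefore expected to give 150 nM, with a range from 30 nM to 1500 nM.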

Compound 4, half-maximal inhibitory concentration: 81 nM
Compound 4: middle estimate off by 1.9-fold (0.27 log units), on the high side, within the range that was stated.
By their numbers in this assay, from the lowest: compounds 1 and 4 (each within the scatter of the next); then compounds 2 and 3 (each within the scatter of the next).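

In this assay, the group on the carbonyl carbon could be exchanged with no readable shift: replacing the methoxy(methyl)amino group with a six-membered non-aromatic ring with 2 hetero atoms, closed through the same nitrogen and oxygen, gives a 1.2-fold higher number from compound 1 to compound 4 (0.09 log units; within the scatter) and nothing beyond the scatter. For the compounds shown here, this is the first comparison in the account that differs in one place only, and it shows that at this position neither the added ring nor the larger group entering on the carbonyl carbon separates compound 4 from compound 1. No measurement at hand explains why the two groups read alike.

The compounds shown leave open whether this position would accept groups of a different kind, such as an amine or a carboxylic acid carried on a longer chain, or a ring of another size closed through the same nitrogen and oxygen. They also leave open whether the same exchange would read alike if the remainder of compound 1 were changed elsewhere, as both compounds in this step share that remainder.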